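This account rests on a few compounds, and the source may have more. Where it says the series, first, only, none or still open, it means among the compounds named here.

Three compounds share one core and differ only in the group attached to a saturated ring carbon. Compound 1 `Cc1nn(-c2ncnc3nc[nH]c23)c2c1C(C(=O)NCc1ccccc1)CC(=O)N2` carries a benzylcarbamoyl group there; in a functional assay on HEK293 cells for agonist activity at G-protein coupled receptor 39 (Homo sapiens), read by scintillation proximity assay and inositol phosphate accumulation, with a stated time of 75 min, in the presence of a further agent that is not named here (on this read-out lower numbers stand for an effect already at smaller amounts and higher numbers for an effect only at larger amounts of compound), compound 1 gives 5 nM. Compound 2 `Cc1nn(-c2ncnc3nc[nH]c23)c2c1C(NC(=O)Cc1cccs1)CC(=O)N2`, with a (((thiophen-2-yl)methyl)carbonyl)amino group in that place, gives 3 nM in this assay, and compound 3 `Cc1nn(-c2ncnc3nc[nH]c23)c2c1C(OC(=O)c1ccc(F)cc1)CC(=O)N2`, with a ((4-fluorophenyl)carbonyl)oxy group there, gives 4 nM. On the numbers shown compound 2 stands at the lowest value, but the gaps to the others are small: a 1.7-fold lower number from compound 1 to compound 2 (0.22 log units; within the scatter) and a 1.3-fold higher number from compound 2 to compound 3 (0.12 log units; within the scatter), so all three sit within the usual spread of repeated measurements.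

Compound 4 `CCC(C(=O)NC1CC(=O)Nc2c1c(C)nn2-c1ncnc2nc[nH]c12)c1ccccc1` keeps the carbonyl and the amide-type nitrogen of compound 2 and alters only the group on that carbonyl carbon: 1-phenylpropyl in place of (thiophen-2-yl)methyl on a carbonyl carbon. The two measured steps bear on this. They show that even exchanging the whole side group on that saturated ring carbon shifted the read-out by less than the scatter. In this assay the step expected from this smaller change is a 1.3-fold higher number from compound 2 to compound 4 (0.12 log units; within the scatter), none beyond the scatter. Compound 4 is therefore estimated at 4 nM, with a likely range from 1.5 nM to 12 nM.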

Compound 4, half-maximal effective concentration: 5 nM
Compound 4: the middle estimate sits 1.3-fold (0.10 log units) below what was measured, and the stated range covers the measured number.
By their numbers in this assay, from the lowest: compounds 2, 3, 1 and 4 (each within the scatter of the next).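

Exchanging (thiophen-2-yl)methyl for 1-phenylpropyl on a carbonyl carbon whose other neighbour is the amide-type nitrogen gives a 1.7-fold higher number from compound 2 to compound 4 (0.22 log units; within the scatter) in this assay. The earlier compounds shown here changed the whole side group, whereas this step keeps the carbonyl and the nitrogen and shows that the read-out also stays within the scatter when only the part beyond them changes, even with a six-membered aromatic ring of carbon only replacing the sulfur-containing five-membered one. Nothing measured here explains this result.

As far as these compounds go, all four values lie within the scatter of one another, so it remains open which change at this place, if any, would move the number beyond it. A methyl group on that carbonyl carbon, or a longer chain ending in an amine or a carboxylic acid, would be a different kind of group from any shown here.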